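The compounds below may be only part of what the source reports. "The series", "measured", "known", "first", "only" and "open" are said of these compounds alone.

Measured so far in a functional assay on SGC-7901 cells (Homo sapiens) for cytotoxicity, read by MTT assay, with a stated time of 72 h; on this read-out higher numbers stand for weaker inhibition and lower numbers for stronger inhibition:
- compound 1 (`CC(C)NC(=S)N/N=C1\CC(c2ccc(O)cc2)Oc2cc(O)ccc21`) gives 35200 nM
- compound 2 (`CC(C)(C)NC(=S)N/N=C1\CC(c2ccc(O)cc2)Oc2cc(O)ccc21`) gives 31000 nM

Compound 2 stands within the scatter of compound 1, so these two values give no order. Going by the values given here, the only measured step, methyl in place of hydrogen on a saturated chain carbon, is a 1.1-fold lower number from compound 1 to compound 2 (0.06 log units; within the scatter). The next change leads to compound 3 (`Oc1ccc(C2C/C(=N\NC(=S)N3CCCC3)c3ccc(O)cc3O2)cc1`), with pyrrolidin-1-yl in place of (tert-butyl)amino on a thiocarbonyl carbon. Among the compounds with values here, no measured compound carries a ring at this place, so the measured step is only a weak guide. With that limitation, no step beyond the scatter is expected in this assay, and no direction is firmly indicated. The expected change is a 1.3-fold lower number from compound 2 to compound 3 (0.11 log units; within the scatter). For compound 3 the estimated value is 24000 nM, with an expected range from 7000 nM to 70000 nM.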

Compound 3, half-maximal inhibitory concentration: 37000 nM
Beside the measured number, compound 3's estimate is 1.5-fold (0.19 log units) below it, and the stated range covers the measured number.
By their numbers in this assay, from the lowest: compounds 2, 1 and 3 (each within the scatter of the next).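

In this assay, the first ring at this place, pyrrolidin-1-yl on the thiocarbonyl carbon, gives no readable shift from either open-chain amine: the record shows a 1.2-fold higher number from compound 2 to compound 3 (0.08 log units; within the scatter) and also a 1.1-fold higher number from compound 1 to compound 3 (0.02 log units; within the scatter) as steps. This change also removes the hydrogen-bond donor carried by (tert-butyl)amino, so at this place neither the closed ring nor the lost donor moves the number beyond the scatter in these three compounds. No measured evidence on the cause of this flat result is available here.

On these data alone, whether morpholin-4-yl, piperidin-1-yl or phenylamino on the thiocarbonyl carbon would give a step beyond the scatter remains open. As far as these compounds go, the contribution of the two hydroxyl groups on the shared core also remains open, as they are the same in all three compounds.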